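Removing the Trifluoromethyl Group from a Succinimide Amide

The source may hold more compounds than are shown below. What is called first, only, known or untested is meant among the compounds shown, and "the series" means these compounds.

Measured compounds in a functional assay on the whole organism (strain Swiss) with Mus musculus as the target, in the maximal electroshock model, with a stated time of 2 h, at a dose of 300 mg/kg by the intraperitoneal route; on this read-out lower numbers stand for a weaker effect and higher numbers for a stronger effect at the one dose given:
Compound 1 `CCC(C(=O)N1CCN(c2cccc(F)c2)CC1)N1C(=O)CCC1=O` gives 0%.
Compound 2 `CCC(C(=O)N1CCN(c2ccccc2F)CC1)N1C(=O)CCC1=O` gives 0%.
Compound 3 `CCC(C(=O)N1CCN(c2ccccc2C(F)(F)F)CC1)N1C(=O)CCC1=O` gives 0%.

Compound 3 thus stands level with compounds 1 and 2; none of the three shows any effect in this assay. The two measured steps, no change at the digits printed from compound 1 to compound 2 (within the scatter) and no change at the digits printed from compound 2 to compound 3 (within the scatter), were both flat, so changing the substituent on the aromatic ring has so far made no difference.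

Compound 4 `CCC(C(=O)N1CCN(c2ccccc2)CC1)N1C(=O)CCC1=O` differs from compound 3 by hydrogen in place of trifluoromethyl on an aromatic carbon. The step of no change at the digits printed from compound 2 to compound 3 (within the scatter) is the one that bears on this, as it also swapped the group on an aromatic carbon, and it gave nothing. Compound 4 is therefore expected to show no step beyond the scatter, no change at the digits printed from compound 3 to compound 4 (within the scatter). Compound 4 is estimated at 0%, in the range 0% to 20%.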

Compound 4, a percentage reported as activity, at one dose (the size of the read-out at that dose, not a potency): 25%
Compound 4: the middle estimate sits 25 percentage points below what was measured; measured number above the stated range.
By their numbers in this assay, from the lowest: compounds 1, 2 and 3 (each within the scatter of the next); then compound 4.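

In this assay, among these compounds, having only hydrogen on the aromatic ring is the first change that moves the read-out: the data show a number 25 percentage points higher from compound 3 to compound 4 (beyond the scatter) when trifluoromethyl leaves, and a number 25 percentage points higher from compound 2 to compound 4 (beyond the scatter) and a number 25 percentage points higher from compound 1 to compound 4 (beyond the scatter) when fluoro leaves. Among these four compounds, swapping one of these groups for another changed nothing, whereas removing the group altogether did. No measurement here accounts for this gain. Going by these compounds, whether a methyl group, a methoxy group or an amine on the ring would keep or lose the activity remains open.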